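The compounds below may be only part of what the source reports. "The series", "measured", "known", "first", "only" and "open" are said of these compounds alone.

In a functional assay on HepG2 cells (Homo sapiens) for inhibition, read by MTT assay, with a stated time of 48 h (on this read-out lower numbers stand for stronger inhibition and higher numbers for weaker inhibition), the three measured compounds give these values:

Compound 1, `COc1cc(/C=N/Nc2nc(-c3ccc(Br)cc3)cs2)cc(Br)c1OC`: 64600 nM
Compound 2, `COc1cc(/C=N/Nc2nc(-c3cccc(Br)c3)cs2)cc(Br)c1OC`: 66200 nM
Compound 3, `Fc1ccc(/C=N/Nc2nc(-c3cccc(Br)c3)cs2)cc1F`: 16700 nM

Compound 2 and compound 1 differ in a single place: 4-bromophenyl in place of 3-bromophenyl on an aromatic carbon
That change made a step of a 1.0-fold lower number from compound 2 to compound 1 (0.01 log units; within the scatter). In other words, moving the bromine around the ring left the result essentially unchanged.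

Compound 3 has a different core from compound 2; how the two cores differ is not broken down here. Compound 3 does stand apart in its own right, as its value is beyond the scatter from both compound 1 and compound 2.

Compound 4, `Fc1ccc(/C=N/Nc2nc(-c3ccc(Br)cc3)cs2)cc1F`, has not yet been measured. It differs from compound 3 in exactly the same way: 4-bromophenyl in place of 3-bromophenyl on an aromatic carbon
Because the step of a 1.0-fold lower number from compound 2 to compound 1 (0.01 log units; within the scatter) was within the scatter, the same change is expected to produce a similarly small step from compound 3 to compound 4, estimated as a 1.0-fold higher number from compound 3 to compound 4 (0.01 log units; within the scatter). Compound 4 is therefore estimated to give about 17000 nM, with a likely range from 8000 nM to 36000 nM.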

Compound 4, half-maximal inhibitory concentration: > 100000 nM
Compound 4 ended at the assay's limit; the forecaster's own chance of this, stated with the estimate: 2%; middle value at least 5.8-fold (0.76 log units) away from the limit.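

In this assay compound 4 gives > 100000 nM, which is a limit of the assay and not a number. Replacing 3-bromophenyl with 4-bromophenyl gave an at least 5.9-fold higher number from compound 3 to compound 4 (0.77 log units; beyond the scatter), so a swap that made no clear difference on the core of compound 2 does not behave the same way on the core of compound 3: the same change on two cores in this assay, a 1.0-fold lower number (0.01 log units; within the scatter) from compound 2 to compound 1 and an at least 5.9-fold higher number (0.77 log units; beyond the scatter) from compound 3 to compound 4, at least 6.1-fold (0.78 log units) apart, beyond the scatter of two such steps. This rests on a single pair of cores and does not show why the two cores respond differently, and the full size of the step remains unknown, as the result for compound 4 stops at a limit: the limit of > 100000 nM in this assay, at which 1 of the 4 values shown sits.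

The compounds shown leave open whether the swap would matter on any other core, and which part of the core decides the outcome. Also open, from the compounds shown here alone, is how this assay would respond if an amine or a carboxylic acid took the place of the bromine on this phenyl ring.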